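The source may hold more compounds than are shown below. What is called first, only, known or untested is meant among the compounds shown, and "the series" means these compounds.

Measured compounds in a functional assay on G-361 cells (Homo sapiens) for antiproliferative activity, with a stated time of 72 h; a lower number here means a stronger inhibitor, a higher number a weaker inhibitor:

compound 1 `OC[C@H]1O[C@@H](n2cnc3c(NCc4ccc(Br)cc4)ncnc32)[C@H](O)[C@@H]1O`: > 166000 nM
compound 2 `COc1cccc(CNc2ncnc3c2ncn3[C@@H]2O[C@H](CO)[C@@H](O)[C@H]2O)c1`: "not determined" (no result reported)
compound 3 `OC[C@H]1O[C@@H](n2cnc3c(NCc4cc(F)cc(F)c4)ncnc32)C(O)C1O`: > 166000 nM

The three compounds share one core and differ only in the group carried on the benzylamine. For compound 1 the result is a limit of this assay, > 166000 nM. For compound 3 the result is likewise a limit, > 166000 nM. Among the compounds with values here, compound 2 stands apart from both: in this assay no result was reported for compound 2, so no single number places it, and the only other values shown are limits. The weight of what is known sits at the limit of > 166000 nM in this assay, at which 2 of the 3 values shown sit.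

Compound 4 `COc1cccc(CNc2ncnc3c2ncn3[C@@H]2O[C@H](CO)[C@@H](O)[C@H]2O)c1O` has not yet been measured. It differs from compound 2 by a single change, (hydroxy in place of hydrogen on an aromatic carbon). Within the data shown here, since no step between two measured compounds is known, there is nothing to set the size or direction of this change; the expectation is a step in this assay no larger than the usual scatter, and most likely a limit again. On that basis compound 4 is estimated at 120000 nM, with a range from 20000 nM to 400000 nM.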

Compound 4, half-maximal inhibitory concentration: 148000 nM
Estimate against measurement, compound 4: 1.2-fold (0.09 log units) below, and the stated range covers the measured number.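

In this assay compound 4 gives 148000 nM, a single number rather than a limit, so the 2-hydroxy-3-methoxyphenyl group places this series on the scale of the assay for the first time among the compounds shown. Measured against the 4-bromophenyl group of compound 1, whose value is a limit, the result is an at least 1.1-fold lower number from compound 1 to compound 4 (0.04 log units; that floor lies within the scatter), so this comparison sets only a floor and does not separate the two groups beyond the scatter. The effect of hydroxy in place of hydrogen cannot be read, as compound 2 has no reported result, and most of what is known still sits at the ceiling: the limit of > 166000 nM in this assay, at which 2 of the 4 values shown sit.

The compounds shown leave open what the hydroxy group contributes on its own, as no measured pair differs by that change alone. They also leave open how an amine or a carboxylic acid on the same aromatic carbon, ortho to the methoxy group, would read in this assay.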